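A few compounds are considered here, and "the series" means these few. Any claim that something is new, unique, unknown or untested is made for them only; others in the source may bear on it.

Measured so far in a functional assay on HT-29 cells (Homo sapiens) for cytotoxicity, read by sulforhodamine B assay, with a stated time of 48 h; a lower number here means a stronger inhibitor, a higher number a weaker inhibitor:

Compound 1, `Cc1ccccc1OS(=O)(=O)c1cccc(NC(=O)NCCCCl)c1`, gives 21000 nM.
Compound 2, `CCc1ccccc1OS(=O)(=O)c1cccc(NC(=O)NCCCCl)c1`, gives 23000 nM.
Compound 3, `CCNC(=O)Nc1ccc(S(=O)(=O)Oc2ccccc2CC)cc1`, gives 12000 nM.

Compound 1 and compound 2 share a core and differ in one place only: methyl in place of hydrogen on a saturated chain carbon bound to an aromatic carbon. This change moved the read-out by a 1.1-fold higher number from compound 1 to compound 2 (0.04 log units; within the scatter), so within the usual scatter the two compounds are not told apart.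

Compound 3 stands on a different core; the difference between the two cores is not broken down here. Its value lies within the scatter of both compound 1 and compound 2, so no order among the three compounds can be claimed.

Compound 4, `CCCc1ccccc1OS(=O)(=O)c1ccc(NC(=O)NCC)cc1`, has not yet been measured. It is related to compound 3 by methyl in place of hydrogen on a saturated chain carbon, two bonds along the chain from an aromatic carbon. Within the data shown here, this is the same kind of change as the one from compound 1 to compound 2, but not the same: there the methyl enters on a saturated chain carbon bound to an aromatic carbon, here it enters on a saturated chain carbon two bonds along the chain from an aromatic carbon.

The expected step in this assay is a 1.1-fold higher number from compound 3 to compound 4 (0.03 log units; within the scatter), resting on a 1.1-fold higher number from compound 1 to compound 2 (0.04 log units; within the scatter), which stayed within the scatter. Since compound 3 gives 12000 nM, compound 4 is expected to give about 13000 nM, with a likely range from 6000 nM to 28000 nM.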

Compound 4, half-maximal inhibitory concentration: 2400 nM
For compound 4 the middle estimate is 5.4-fold (0.73 log units) above the measured one; measured number outside the range, below it.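

In this assay the added methyl turns the ethyl of compound 3 into the propyl of compound 4 and gives a 5.0-fold lower number from compound 3 to compound 4 (0.70 log units; beyond the scatter) on that core, so one extra carbon on this chain can matter in this cell assay. This does not show why the change behaves as it does: the two steps differ in their core and also in where the methyl enters, and a single pair on each core cannot separate these two differences or establish a general rule for either core. What can be said is that the step measured on one core did not carry over to the other, so a small step on one core is no safe guide to the size of the step on another: the same change on two cores in this assay, a 1.1-fold higher number (0.04 log units; within the scatter) from compound 1 to compound 2 and a 5.0-fold lower number (0.70 log units; beyond the scatter) from compound 3 to compound 4, 5.5-fold (0.74 log units) apart, beyond the scatter of two such steps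

The compounds shown leave open whether a propyl group on the core of compound 1 would bring the same gain, which would help to separate the effect of the core from that of the place of the methyl. They also leave open whether the gain continues with a longer chain such as butyl, or what happens with an amine or a carboxylic acid at the end of the chain.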